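A Stereocentre Left Undrawn

A few compounds are considered here, and "the series" means these few. Any claim that something is new, unique, unknown or untested is made for them only; others in the source may bear on it.

Compound 1 `Cc1ccc(N(CC(C)C)S(=O)(=O)c2ccc3c(c2)C(=O)CC(C2CCOCC2)O3)c(C)c1` gives 4.28
Compound 2 `CCc1ccc(N(CC(C)C)S(=O)(=O)c2ccc3c(c2)C(=O)C[C@@H](C2CCOCC2)O3)cc1` gives 4.2

In a physicochemical assay for lipophilicity, at pH 7.4 (a lower number here means a more polar compound, a higher number a more lipophilic compound), compound 2 gives 4.2 and compound 1 gives 4.28 in the same kind of measurement, a gap within the usual scatter, so the two stand level. Compound 3 `CCc1ccc(N(CC(C)C)S(=O)(=O)c2ccc3c(c2)C(=O)CC(C2CCOCC2)O3)cc1` has the same atoms and bonds as compound 2, and the only difference lies in how one centre is drawn (the two compounds have the same atoms and bonds; at least one stereo element is drawn with a configuration in one of them and without one in the other: 1 of 1 stereo elements differ; a stereocentre at a saturated ring carbon is drawn S in compound 2 and without a configuration in compound 3). Within the data shown here, no measured pair shows what such a difference does, but no step beyond the scatter is expected in this assay (estimated: no change at the digits printed from compound 2 to compound 3 (within the scatter)). Compound 3 is estimated at 4.2 with an expected range from 3.95 to 4.45 here.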

Compound 3, distribution coefficient: 4.21
Compound 3: middle estimate off by 0.01 log units, on the low side; the measured number falls inside the stated range.
By their numbers in this assay, from the lowest: compounds 2, 3 and 1 (each within the scatter of the next).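

In this assay, the stereocentre at the saturated ring carbon is drawn S in one compound and left undrawn in the other, and the result is a number 0.01 log units higher from compound 2 to compound 3 (within the scatter). Placing 4-ethylphenyl where 2,4-dimethylphenyl stood on the sulfonamide nitrogen gives a number 0.07 log units lower from compound 1 to compound 3 (within the scatter), so neither change separates the compounds in this assay. The stereochemical comparison rests on a difference in drawing alone: the fact that one of compounds 2 and 3 is drawn with a defined configuration and the other without, at the place where they differ.

Going by these compounds, the composition of the undrawn material remains unknown, as does the value of a compound drawn with the opposite configuration. Also open, on these data alone, is whether an amine or a carboxylic acid on that phenyl ring would shift the number.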